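The source may hold more compounds than are shown below. What is called first, only, known or untested is meant among the compounds shown, and "the series" means these compounds.

Measured compounds:
compound 1 `Cc1ccc(-c2cc(C(=O)Nc3ccc(Oc4ccnc5[nH]ccc45)cc3)ncn2)cc1` gives 5410 nM
compound 2 `O=C(Nc1ccc(Oc2ccnc3[nH]ccc23)c(F)c1)c1cc(-c2ccccc2)ncn1` gives 180 nM
compound 3 `O=C(Nc1ccc(Oc2ccnc3[nH]ccc23)c(F)c1)c1cc(-c2ccc(C(F)(F)F)cc2)ncn1` gives 2220 nM

In a functional assay on A549 cells (Homo sapiens) for cytotoxicity, read by MTT assay, with a stated time of 72 h (a higher number here means a weaker inhibitor, a lower number a stronger inhibitor), compound 3 stands second highest of the three numbers; its nearest neighbour is compound 1 and its furthest is compound 2. Within the data shown here, the one step among measured pairs that reaches compound 3 is the one from compound 2, where the change reads a 12-fold higher number from compound 2 to compound 3 (1.09 log units; beyond the scatter).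

Compound 4 `Cc1ccc(-c2cc(C(=O)Nc3ccc(Oc4ccnc5[nH]ccc45)c(F)c3)ncn2)cc1` differs from compound 3 by methyl in place of trifluoromethyl on an aromatic carbon. Among the measured compounds shown here, no measured pair shows methyl against trifluoromethyl directly; the step from compound 2 to compound 3 compares trifluoromethyl with hydrogen only, and shows that the trifluoromethyl compound sits well above the unsubstituted one. Compound 1 carries the same methyl group as compound 4 but differs from it elsewhere, so its number cannot be read as a step; it only shows that a methyl compound of this series can lie at the weak end.

With the trifluoromethyl removed, compound 4 is expected to come out near compound 3 or somewhat lower, at an estimated 1500 nM with a range from 400 nM to 5500 nM. The expected step reads a 1.5-fold lower number from compound 3 to compound 4 (0.17 log units; within the scatter), which is taken to stay within the scatter.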

Compound 4, half-maximal inhibitory concentration: 8600 nM
Compound 4: the middle estimate sits 5.7-fold (0.76 log units) below what was measured, and the stated range ends below it.
By their numbers in this assay, from the lowest: compound 2; then compound 3; then compounds 1 and 4 (each within the scatter of the next).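

In this assay, among these compounds, the step of a 3.9-fold higher number from compound 3 to compound 4 (0.59 log units; beyond the scatter) gives the first direct reading of methyl against trifluoromethyl on this carbon, para to a large group, and the 4-methylphenyl compound holds the higher number of the pair. The step of a 48-fold higher number from compound 2 to compound 4 (1.68 log units; beyond the scatter) then places both substituted compounds above the unsubstituted phenyl compound, so among compounds 2, 3 and 4 hydrogen gives the lowest number and neither substituent comes close to it, with methyl the further away. The step of a 1.6-fold higher number from compound 1 to compound 4 (0.20 log units; within the scatter) stays within the scatter, so fluoro in place of hydrogen on the aromatic carbon of the shared core does not separate the two methyl compounds. No measurement in hand offers an explanation for these steps.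

Among the compounds shown here, whether fluoro leaves the number equally unchanged when this carbon carries hydrogen or trifluoromethyl stays open, since the only pair that reads it carries methyl. How an amine, a carboxylic acid or a methoxy group on this carbon would compare with hydrogen also stays open, as does whether the order seen among these three compounds extends to any such group.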